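The compounds below may be only part of what the source reports. "The series", "measured", "known", "first", "only" and "open" are said of these compounds alone.

Of the compounds shown here, three sharing a common core have been measured in a physicochemical assay for acid dissociation. Compound 1 `COc1ccc(F)cc1CNCCCNc1ccnc2cc(CCC(C)C)ccc12` gives 9.47 in this assay, compound 3 `COc1ccc(F)cc1CNCCCNc1ccnc2cc(CCc3ccccc3)ccc12` gives 9.47, and compound 2 `Fc1ccc(-c2ccc3c(NCCCNCc4ccco4)ccnc3c2)cc1` gives 9.47. Compound 2 thus stands level with compounds 1 and 3 at the digits shown, with compound 1 nearest and compound 3 furthest, both within the scatter. Among the measured compounds shown here, the only measured step, no change at the digits printed from compound 1 to compound 3 (within the scatter), exchanges phenyl for isopropyl on a saturated chain carbon, two bonds along the chain from an aromatic carbon, and leaves the acid dissociation constant unchanged within the scatter.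

Compound 4 `COc1ccc(-c2ccc3c(NCCCNCc4ccco4)ccnc3c2)cc1` is next to be measured. It differs from compound 2 by methoxy in place of fluoro on an aromatic carbon, the change sitting on an aromatic carbon of a six-membered aromatic ring of carbon only. The step from compound 1 to compound 3 is the only one bearing on this, and it was flat, so there is no ground to expect a step beyond the scatter in this assay. Compound 4 is therefore expected to give 9.47, with a range from 9.2 to 9.75. The step this implies, no change at the digits printed from compound 2 to compound 4 (within the scatter), is expected to lie within the scatter.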

Compound 4, acid dissociation constant: 9.47
Estimate against measurement, compound 4: no gap at the digits printed, within the range that was stated.
By their numbers in this assay, from the lowest: compounds 1, 2, 3 and 4 (each within the scatter of the next).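

In this assay, methoxy in place of fluoro on an aromatic carbon of a six-membered aromatic ring of carbon only, para to a large group, gives no change at the digits printed from compound 2 to compound 4 (within the scatter). This is the first step shown at an aromatic position rather than on a saturated chain carbon, and it shows that the read-out stays level here even when the entering group brings a hydrogen-bond acceptor that fluoro lacks. No evidence is available that bears on this result.

On these data alone, whether this position would stay level with an amine or a carboxylic acid in place of methoxy remains open. As far as these compounds go, it is equally open whether a longer chain, such as butoxy, would leave the step within the scatter.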